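Phenyl in Place of Thiophen-2-yl on the Seven-Membered Ring

The source may report more compounds than this note shows. Statements on the series, on what has been measured and on what is new or still open speak of the compounds shown alone.

Of the compounds shown here, three on a shared core have been measured in a functional assay on NB-4 cells (Homo sapiens) for cytotoxicity, read by CCK-8 assay, with a stated time of 24 h; on this read-out higher numbers stand for weaker inhibition and lower numbers for stronger inhibition. Compound 1 `C=CC(=O)N1C(=O)CC(C)Sc2ccccc21` gives 227000 nM. Compound 2 `C=CC(=O)N1C(=O)CC(c2ccccc2C(F)(F)F)Sc2ccccc21` gives 35200 nM. Compound 3 `C=CC(=O)N1C(=O)CC(c2cccs2)Sc2ccccc21` gives 765000 nM, the highest of the three numbers; its nearest neighbour is compound 1, and its furthest is compound 2, both of which lie beyond the scatter below it. Among the compounds with values here, the one single-point step among them, a 3.4-fold higher number from compound 1 to compound 3 (0.53 log units; beyond the scatter), shows that thiophen-2-yl in place of methyl on the saturated ring carbon raised the number by a modest amount.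

Compound 4 `C=CC(=O)N1C(=O)CC(c2ccccc2)Sc2ccccc21` differs from compound 3 by phenyl in place of thiophen-2-yl on a saturated ring carbon. Within the data shown here, no measured step swaps one aromatic ring for another on this carbon; compound 2 and compound 3 merely show that a six-membered aromatic ring carrying trifluoromethyl sits well below thiophen-2-yl on this read-out. Phenyl is expected to land between those two, so a drop in this assay from compound 3 is estimated, most likely beyond the scatter, with considerable uncertainty about its size: a 3.5-fold lower number from compound 3 to compound 4 (0.54 log units; beyond the scatter). Compound 4 is therefore expected to give about 220000 nM, within a range from 60000 nM to 800000 nM.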

Compound 4, half-maximal inhibitory concentration: 35500 nM
The estimate for compound 4 lay 6.2-fold (0.79 log units) above the measured number; the whole stated range lies above it.
By their numbers in this assay, from the lowest: compounds 2 and 4 (each within the scatter of the next); then compound 1; then compound 3.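

In this assay, within the data shown here, the choice of aromatic ring on this saturated ring carbon matters far more than the earlier compounds could show: phenyl in place of thiophen-2-yl gives a 22-fold lower number from compound 3 to compound 4 (1.33 log units; beyond the scatter), a large step, whereas the only earlier step at this carbon was modest. Phenyl in place of methyl gives a 6.4-fold lower number from compound 1 to compound 4 (0.81 log units; beyond the scatter), so phenyl and thiophen-2-yl fall on opposite sides of methyl, and having an aromatic ring on this carbon does not by itself set the direction of the change. Hydrogen in place of trifluoromethyl on an aromatic carbon gives a 1.0-fold higher number from compound 2 to compound 4 (0.00 log units; within the scatter), so the low number seen with the trifluoromethyl-bearing ring does not depend on that group and is matched by unsubstituted phenyl.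

Nothing available here accounts for the wide gap between the two aromatic rings. From the compounds shown here alone, it remains open whether other rings on this carbon, such as pyridin-3-yl, thiophen-3-yl or cyclohexyl, would follow phenyl or thiophen-2-yl, and whether a methoxy group or an amine on the phenyl ring would move the number where trifluoromethyl did not.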